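This account rests on a few compounds, and the source may have more. Where it says the series, first, only, none or still open, it means among the compounds named here.

Going by the values given here, in a physicochemical assay for solubility, measured as kinetic solubility (on this read-out higher numbers stand for higher solubility and lower numbers for lower solubility), compound 2 (`CNC(=O)c1cc(C(=O)N[C@H]2CC[C@H](O)CC2)n([C@@H](C)c2cccc(C(F)(F)F)c2)n1`) gives 7 ug/mL as the only true number so far. Compound 1 (`CNC(=O)c1cc(C(=O)N[C@H]2CC[C@H](O)CC2)n([C@@H](C)c2ccc(Cl)cc2)n1`) gives >= 132 ug/mL as its reading, and that is a limit of the assay, not a number. Among the compounds with values here, the one measured step (an at least 18-fold lower number from compound 1 to compound 2 (1.27 log units; beyond the scatter)) is large and brought in 3-(trifluoromethyl)phenyl in place of 4-chlorophenyl. Compound 3 (`CNC(=O)c1cc(C(=O)N[C@H]2CC[C@H](O)CC2)n([C@@H](C)c2ccc(C(F)(F)F)cc2)n1`) has 4-(trifluoromethyl)phenyl in place of 3-(trifluoromethyl)phenyl on a saturated chain carbon bound to an aromatic nitrogen and a saturated chain carbon. It keeps the trifluoromethyl of compound 2 yet shares a 4-substituted phenyl with compound 1. The measured step (an at least 18-fold lower number from compound 1 to compound 2 (1.27 log units; beyond the scatter)) changed both features at once, so only part of that drop is expected to return. The expected change is a moderate rise (a 3.6-fold higher number from compound 2 to compound 3 (0.55 log units; beyond the scatter)) in this assay. Compound 3 is estimated at 25 ug/mL with an expected range from 7 ug/mL to 120 ug/mL around that value.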

Compound 3, solubility: >= 175 ug/mL
Compound 3 ended at the assay's limit (the forecaster's own chance of this, stated with the estimate: 15%); at least 7.0-fold (0.84 log units) between middle value and limit.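

Swapping 3-(trifluoromethyl)phenyl for 4-(trifluoromethyl)phenyl on the saturated chain carbon, with the same atoms joined differently, gives an at least 25-fold higher number from compound 2 to compound 3 (1.39 log units; beyond the scatter) in this assay, so the trifluoromethyl group alone does not set the low reading of compound 2; how it is joined to the phenyl ring matters as well. Compound 3 sits at a limit of the assay, not at a true number: the limit of >= 175 ug/mL in this assay, at which 1 of the 3 values shown sits. Compound 1 also sits at a limit, so the step from compound 1 to compound 3 cannot be read: the limit of >= 132 ug/mL in this assay, at which 1 of the 3 values shown sits.

On these data alone, the true readings of compound 1 and compound 3 therefore remain unknown. As far as these compounds go, it is also open how the reading would change with an amine or a carboxylic acid in place of the trifluoromethyl on the phenyl ring.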